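Thiophene in place of dimethylphenyl on the pyrazoline core

The source may hold more compounds than are shown below. What is called first, only, known or untested is meant among the compounds shown, and "the series" means these compounds.

Of the compounds shown here, three sharing one core have been measured in a functional assay on WM 266-4 cells (Homo sapiens) for antiproliferative activity, read by MTT assay, with a stated time of 48 h; on this read-out higher numbers stand for weaker inhibition of growth and lower numbers for stronger inhibition of growth. Compound 1 `Fc1ccc(C2=NN(C(=S)Nc3ccccc3)C(c3ccc4c(c3)OCCO4)C2)cc1` gives 22500 nM in this assay. Compound 2 `S=C(Nc1ccccc1)N1N=C(c2ccc(Cl)c(Cl)c2)CC1c1ccc2c(c1)OCCO2` gives 58700 nM in this assay. Compound 3 `Cc1ccc(C2=NN(C(=S)Nc3ccccc3)C(c3ccc4c(c3)OCCO4)C2)cc1C` gives 70500 nM in this assay, the highest of the three numbers; its nearest neighbour is compound 2, and the gap to compound 1 is the widest of the set. The recorded steps all swap the aryl group on the carbon with a double bond to nitrogen: a 2.6-fold higher number from compound 1 to compound 2 (0.42 log units; beyond the scatter) and a 3.1-fold higher number from compound 1 to compound 3 (0.50 log units; beyond the scatter) were modest and beyond the scatter, while a 1.2-fold higher number from compound 2 to compound 3 (0.08 log units; within the scatter) stayed within it.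

Compound 4 `S=C(Nc1ccccc1)N1N=C(c2cccs2)CC1c1ccc2c(c1)OCCO2` differs from compound 3 by thiophen-2-yl in place of 3,4-dimethylphenyl on a carbon with a double bond to nitrogen. Within the data shown here, every step so far concerns the same position, so they bear directly on this change; none of them exceeded a modest size, and none involved a five-membered ring with a hetero atom, so the direction of the new step is open. A modest step of either sign is therefore expected, which is what a 2.0-fold lower number from compound 3 to compound 4 (0.30 log units; within the scatter) expresses. On that basis compound 4 is estimated to give 35000 nM in this assay, with a range from 10000 nM to 120000 nM.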

Compound 4, concentration for 50% growth inhibition: 154000 nM
Beside the measured number, compound 4's estimate is 4.4-fold (0.64 log units) below it; the measured number lies above the stated range.
By their numbers in this assay, from the lowest: compound 1; then compounds 2 and 3 (each within the scatter of the next); then compound 4.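

In this assay, the step to the thiophen-2-yl group raises the number whichever aryl group it replaces: a 2.2-fold higher number from compound 3 to compound 4 (0.34 log units; beyond the scatter) and a 2.6-fold higher number from compound 2 to compound 4 (0.42 log units; beyond the scatter) and a 6.8-fold higher number from compound 1 to compound 4 (0.84 log units; beyond the scatter) are all beyond the scatter, which makes compound 4 the weakest inhibitor of growth of the four. Among these compounds, the earlier compounds compared only six-membered aromatic rings of carbon at this position, so this is the first sign that a five-membered aromatic ring with a sulfur atom can stand here and that it gives a higher number than all three of them, although every step remains modest in size. Nothing available explains this rise.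

A single thiophen-2-yl compound cannot separate the part played by ring size from that played by the sulfur atom, and an unsubstituted phenyl, a furan-2-yl or a pyridin-3-yl group at the same carbon would help to tell them apart. Going by these compounds, it also remains open whether a 4-aminophenyl or 4-carboxyphenyl group could bring the number below that of compound 1 , or whether the trend holds when the other groups on the shared core change.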